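Same Ring Change Carried onto a Second Core

The source may report more compounds than this note shows. Statements on the series, on what has been measured and on what is new or still open speak of the compounds shown alone.

Four compounds are compared in a functional assay on the whole organism (strain albino) for inhibition, with Rattus norvegicus as the target, read by paw edema, with stated times of 30 min and 2 h, at a dose of 100 mg/kg by the oral route; on this read-out higher numbers stand for more inhibition at the one dose given (going by the name of the read-out) and lower numbers for less inhibition. Compound 1 `CC(O[N+](=O)[O-])C(=O)Nc1ccc(C(=O)/C=C/c2ccc(Cl)cc2)cc1` gives 55%. Compound 2 `COc1ccc(/C=C/C(=O)c2ccc(NC(=O)C(C)O[N+](=O)[O-])cc2)cc1` gives 46% in this assay. The change between them is methoxy in place of chloro on an aromatic carbon and the step it made is a number 9 percentage points lower from compound 1 to compound 2 (within the scatter). Compound 3 `CC(=O)c1ccc(OCC(=O)Nc2ccc(C(=O)/C=C/c3ccc(Cl)cc3)cc2)cc1` gives 52% in this assay; the difference between the core of compound 3 and the core of compound 1 is not broken down here. Compound 4 `COc1ccc(/C=C/C(=O)c2ccc(NC(=O)COc3ccc(C(C)=O)cc3)cc2)cc1` carries the same change, (methoxy in place of chloro on an aromatic carbon), on the core of compound 3 and has not yet been measured in this assay. For the measured compounds named here, the step from compound 3 is expected to be a number 8 percentage points lower from compound 3 to compound 4 (within the scatter), estimated to mirror the earlier pair because a number 9 percentage points lower from compound 1 to compound 2 (within the scatter) is the only example of this change with numbers on both sides. Compound 4 is therefore expected to give 44%, with a likely range from 32% to 56%.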

Compound 4, a percentage reported as inhibition, in the whole organism at one dose (the size of the read-out at that dose, not a potency): 35%
Compound 4: the middle estimate sits 9 percentage points above what was measured, and the stated range covers the measured number.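

Methoxy in place of chloro on the second core gives a number 17 percentage points lower from compound 3 to compound 4 (beyond the scatter) in this assay. Set beside the step on the first core, it points the same way, and the gap between the two stays within what repeated measurement allows: the same change on two cores in this assay, a number 9 percentage points lower (within the scatter) from compound 1 to compound 2 and a number 17 percentage points lower (beyond the scatter) from compound 3 to compound 4, 8 percentage points apart, within the scatter of two such steps. The change therefore carries over in direction on these two cores, but two pairs read at one dose do not show that its size is fixed or that it depends on the core, and they do not say why the number falls.

On these data alone, only chloro and methoxy appear at this place, so what an amine or a carboxylic acid there would give remains open. As far as these compounds go, how the change behaves on a third core also remains open.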